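Adding a Second Chloro to a Purine Cytotoxicity Series

A few compounds are considered here, and "the series" means these few. Any claim that something is new, unique, unknown or untested is made for them only; others in the source may bear on it.

Compound 1 `ClCc1ccc(Cn2cnc3c(Cl)ncnc32)cc1` was tested in a functional assay on ACHN cells (Homo sapiens) for cytotoxicity, read by sulforhodamine B assay, with a stated time of 48 h (a higher number here means a weaker inhibitor of growth, a lower number a stronger inhibitor of growth), where compound 1 gives 310 nM. Two further compounds carry a second chloro group on the shared core and a different arrangement of the benzyl part. In this assay compound 2 `ClCc1ccccc1Cn1cnc2c(Cl)nc(Cl)nc21` gives 470 nM, and compound 3 `ClCc1cccc(Cn2cnc3c(Cl)nc(Cl)nc32)c1` gives 1900 nM. Among these three numbers compound 1 has the lowest, but the gap to compound 2 falls within the usual scatter of the measurement, so the two cannot be ranked; only compound 3 lies clearly beyond it, with a weaker effect on cell growth.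

Compound 4 `ClCc1ccc(Cn2cnc3c(Cl)nc(Cl)nc32)cc1` has not yet been measured in this assay. It differs from compound 1 by a single change, chloro in place of hydrogen on an aromatic carbon. Going by the values given here, no measured pair shows this exact change on an otherwise identical scaffold, so its effect has to be guessed from the spread of the three values.

The change is expected to produce a step of a 1.3-fold higher number from compound 1 to compound 4 (0.11 log units; within the scatter) that is small and, most likely, within the scatter. Compound 4 is therefore expected to give about 400 nM in this assay, with a plausible range from 150 nM to 1200 nM.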

Compound 4, concentration for 50% growth inhibition: 2340 nM
For compound 4 the middle estimate is 5.9-fold (0.77 log units) below the measured one, outside the stated range (above it).
By their numbers in this assay, from the lowest: compounds 1 and 2 (each within the scatter of the next); then compounds 3 and 4 (each within the scatter of the next).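

In this assay, placing a chloro group on the aromatic carbon between two ring nitrogen atoms gives a 7.5-fold higher number from compound 1 to compound 4 (0.88 log units; beyond the scatter), a step beyond the scatter and toward weaker inhibition of growth. This position is therefore sensitive: a change of a single atom on the shared core is enough to move the number clearly. The earlier compounds could not show this, as each differed from the others in more than one place, so none separated this chloro group from the arrangement of the benzyl part, and nothing measured here bears on why the step goes in this direction.

From the compounds shown here alone, whether the step belongs to chloro in particular or would follow any group at this position stays open, and an amine, a methoxy group or a fluoro in the same place would help to settle that. Going by these compounds, whether the same change gives a step of similar size with the benzyl arrangement of compound 2 or compound 3 also stays open.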